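The source may hold more compounds than are shown below. What is called first, only, known or untested is meant among the compounds shown, and "the series" means these compounds.

Three measured compounds share a related core. Compound 1 `CCC1C(=O)N(C)c2cnc(-n3ccc4cc(C(=O)NC)ccc43)nc2N1c1ccn(C)n1` and compound 3 `CCNC(=O)c1ccc2c(ccn2-c2ncc3c(n2)N(c2ccn(C)n2)C(CC)C(=O)N3C)c1` differ only in one place: methyl in place of hydrogen on a saturated chain carbon bound to an amide-type nitrogen. In a functional assay on HeLa cells (Homo sapiens) for antiproliferative activity, read by CCK-8 assay, with a stated time of 72 h (a higher number here means a weaker inhibitor of growth, a lower number a stronger inhibitor of growth), compound 1 gives 6330 nM, and compound 3 gives 11100 nM; the step is a 1.8-fold higher number from compound 1 to compound 3 (0.24 log units; within the scatter), so lengthening the chain on the amide there did not change growth inhibition in a way that can be trusted.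

Compound 2 `CCCNC(=O)c1ccc2c(ccn2-c2ncc3c(n2)N(C2CCCC2)[C@H](CC)C(=O)N3C)c1` carries a different core; the difference between the two cores is not broken down here. In this assay compound 2 gives 238 nM, the lowest of the three numbers and well apart from compound 1 and compound 3.

Compound 4 `CCCCNC(=O)c1ccc2c(ccn2-c2ncc3c(n2)N(C2CCCC2)[C@H](CC)C(=O)N3C)c1` is not yet measured. It differs from compound 2 by methyl in place of hydrogen on a saturated chain carbon, three bonds along the chain from an amide-type nitrogen. This is the same kind of change as that from compound 1 to compound 3, but not the same: there the methyl entered on a saturated chain carbon bound to an amide-type nitrogen, whereas here it enters three bonds along the chain from an amide-type nitrogen, so the chain is already longer before the methyl is added. Since the earlier step, a 1.8-fold higher number from compound 1 to compound 3 (0.24 log units; within the scatter), stayed within the scatter, a small step is expected from compound 2 to compound 4, a 1.3-fold higher number from compound 2 to compound 4 (0.10 log units; within the scatter), because compound 2 gives 238 nM and the change is a single added carbon. Compound 4 is therefore expected to give about 300 nM, with a likely range from 120 nM to 750 nM.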

Compound 4, concentration for 50% growth inhibition: 346 nM
For compound 4 the middle estimate is 1.2-fold (0.06 log units) below the measured one; low and high end bracket the measured number.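

In this assay, lengthening the amide chain from propyl to butyl gives a 1.5-fold higher number from compound 2 to compound 4 (0.16 log units; within the scatter), so this step cannot be told apart from the ordinary spread of repeat measurements. Set beside the earlier step, where the chain goes from methyl to ethyl on a different core, the two steps agree: the same change on two cores in this assay, a 1.8-fold higher number (0.24 log units; within the scatter) from compound 1 to compound 3 and a 1.5-fold higher number (0.16 log units; within the scatter) from compound 2 to compound 4, 1.2-fold (0.08 log units) apart, within the scatter of two such steps. This shows that adding a single carbon to this chain left growth inhibition without a trustworthy change in both pairs, but it does not show that the carbon is without effect on every core or at every chain length, and with both steps this small, neither gives a real effect size that could be carried from one core to another.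

The compounds shown leave open what happens when the chain is taken further, for example to a longer chain such as hexyl, a branched chain such as isopropyl, or a chain ending in an amine or a carboxylic acid. They also leave open which structural difference separates the numbers of compound 2 and compound 3, as these two compounds differ in more than one place.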